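The compounds below may be only part of what the source reports. "The series", "measured", "known", "first", "only" and "open" are said of these compounds alone.

Three compounds have been measured so far in an ADME assay on L6 cells (Rattus norvegicus) for cytotoxicity, read by resazurin assay, with a stated time of 72 h; on this read-out lower numbers stand for stronger inhibition and higher numbers for weaker inhibition:

Compound 1, `OC(c1ccc(Cl)cc1)(c1cccnc1)c1cccc(F)c1`, gives 66000 nM.
Compound 2, `OC(c1ccc(Cl)cc1)(c1cccnc1)c1cccc(C(F)(F)F)c1`, gives 60400 nM.
Compound 3, `OC(c1ccc(Cl)cc1)(c1cccnc1)c1ccc(F)cc1F`, gives 70200 nM.

Compound 1 and compound 2 differ in one place only: trifluoromethyl in place of fluoro on an aromatic carbon. This change gave a 1.1-fold lower number from compound 1 to compound 2 (0.04 log units; within the scatter), so the two compounds sit within the scatter of each other in this assay. Compound 3 stands on a different core from compound 1, and the difference between the two cores is not broken down here. Its number in this assay lies within the scatter of both compound 1 and compound 2, so nothing separates the three measured compounds on this read-out.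

Compound 4, `OC(c1ccc(Cl)cc1)(c1cccnc1)c1ccc(C(F)(F)F)cc1F`, has not yet been measured. It is related to compound 3 by the following change: trifluoromethyl in place of fluoro on an aromatic carbon. Among the measured compounds shown here, this is the same kind of change as the one from compound 1 to compound 2, but not the same change: in compound 1 the fluoro sits meta to a large group, whereas in compound 3 it sits meta to a fluoro group and para to a large group. Since the earlier step was a 1.1-fold lower number from compound 1 to compound 2 (0.04 log units; within the scatter), compound 4 is expected to move from compound 3 by about a 1.1-fold lower number from compound 3 to compound 4 (0.04 log units; within the scatter), a step that rests on that single measured pair. Compound 4 is therefore estimated to give 64000 nM in this assay, with the likely range running from 35000 nM to 130000 nM.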

Compound 4, half-maximal inhibitory concentration: 57400 nM
Beside the measured number, compound 4's estimate is 1.1-fold (0.05 log units) above it, and the stated range covers the measured number.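

In this assay, trifluoromethyl in place of fluoro on an aromatic carbon gave a 1.2-fold lower number from compound 3 to compound 4 (0.09 log units; within the scatter). Set side by side, the two steps taken on the two cores do not differ: the same change on two cores in this assay, a 1.1-fold lower number (0.04 log units; within the scatter) from compound 1 to compound 2 and a 1.2-fold lower number (0.09 log units; within the scatter) from compound 3 to compound 4, 1.1-fold (0.05 log units) apart, within the scatter of two such steps. Among the compounds shown here, on these two cores, then, the change carried over in the sense that neither step separates its pair of compounds on this read-out, but that agreement rests on two pairs alone, and since both steps lie within the scatter, it shows only that the change left the number within the scatter twice, not that a step of measurable size would transfer from one core to another or that other cores would behave the same way.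

The compounds shown leave open whether any group other than fluoro and trifluoromethyl at this place, such as an amine, a carboxylic acid or a longer chain, would move the number beyond the scatter. They also leave open whether the same change would still read alike on a core that differs more widely from these two, and whether it would do so on any read-out other than this one.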